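This account rests on a few compounds, and the source may have more. Where it says the series, first, only, none or still open, it means among the compounds named here.

Working notes on the series. Compound 1 `CCCn1c(-c2ccc(OCc3c(-c4c(Cl)cccc4Cl)noc3C(C)C)cc2)nc2ccc(C(=O)O)cc21` gives 9.3 nM in an assay on Huh-7 cells for agonist activity at Bile acid receptor (Homo sapiens), read by a luciferase reporter; a higher number here means that more compound is needed for the effect, a lower number that less compound is needed. Compound 3 `CC(C)c1onc(-c2c(Cl)cccc2Cl)c1COc1ccc(-c2nc3ccc(C(=O)O)cc3n2CC2CCCCC2)c(Cl)c1` gives 7.6 nM, and compound 2 `CC(C)c1onc(-c2c(Cl)cccc2Cl)c1COc1ccc(-c2nc3ccc(C(=O)O)cc3n2C2CC2)cc1` gives 16.5 nM; compound 1 thus holds the second highest of the three numbers, within the scatter of each neighbour. Going by the values given here, the one single-point step measured, from compound 1 to compound 2, reads a 1.8-fold higher number from compound 1 to compound 2 (0.25 log units; within the scatter) for cyclopropyl in place of propyl on an aromatic nitrogen. Compound 4 `CC(=O)C1CCC(Cn2c(-c3ccc(OCc4c(-c5c(Cl)cccc5Cl)noc4C(C)C)cc3)nc3ccc(C(=O)O)cc32)CC1` differs from compound 1 by 4-acetylcyclohexyl in place of ethyl on a saturated chain carbon bound to an aromatic nitrogen. Among the compounds with values here, only the step to compound 2 bears on it, as another change of the group on that nitrogen, and it stayed within the scatter. Compound 4 is therefore expected to give about 12 nM, between 4 nM and 35 nM; the expected step is a 1.3-fold higher number from compound 1 to compound 4 (0.11 log units; within the scatter), not beyond the scatter.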

Compound 4, half-maximal effective concentration: 1170 nM
The estimate for compound 4 lay 98-fold (1.99 log units) below the measured number; measured number above the stated range.
By their numbers in this assay, from the lowest: compounds 3, 1 and 2 (each within the scatter of the next, the first and the last beyond it); then compound 4.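

On the aromatic nitrogen, the group now matters far more than the swap of propyl for cyclopropyl suggested: (4-acetylcyclohexyl)methyl gives a 130-fold higher number from compound 1 to compound 4 (2.10 log units; beyond the scatter) and a 71-fold higher number from compound 2 to compound 4 (1.85 log units; beyond the scatter) in this assay. Small groups at this place therefore do not define how far it can be changed, and a single larger group carrying a carbonyl can move the number well beyond the scatter. Nothing available explains this large step. Still open, from the compounds shown here alone, is whether the acetyl or the cyclohexyl ring accounts for the step. A hydroxyl or an amine in place of the acetyl, on the core of compound 1, would separate the two.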